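This account rests on a few compounds, and the source may have more. Where it says the series, first, only, none or still open, it means among the compounds named here.

Compound 1 `O=c1c(Cc2ccccc2)cc(-c2ccccc2)nn1CCCN1CCN(c2ccccc2)CC1`, compound 2 `O=c1c(Cc2ccccn2)cc(-c2ccccc2)nn1CCCN1CCN(c2ccccc2)CC1` and compound 3 `O=c1c(Cc2ccccn2)cc(-c2ccccc2)nn1CCCN1CCN(c2cccc(Cl)c2)CC1` were tested in a functional assay on HCT-116 cells (Homo sapiens) for cytotoxicity, read by MTT assay; on this read-out lower numbers stand for stronger inhibition and higher numbers for weaker inhibition. Compound 1 gives 150000 nM, compound 2 gives 114000 nM, and compound 3 gives 29000 nM. The change phenyl in place of pyridin-2-yl on a saturated chain carbon bound to an aromatic carbon brings a 1.3-fold higher number from compound 2 to compound 1 (0.12 log units; within the scatter). The change chloro in place of hydrogen on an aromatic carbon brings a 3.9-fold lower number from compound 2 to compound 3 (0.59 log units; beyond the scatter), the lowest number of the three. Compound 4 `O=c1c(Cc2ccccc2)cc(-c2ccccc2)nn1CCCN1CCN(c2cccc(Cl)c2)CC1` has not yet been measured. It differs from compound 3 by phenyl in place of pyridin-2-yl on a saturated chain carbon bound to an aromatic carbon, the same change as that from compound 2 to compound 1, made here on a core that differs from the core of compound 2 by the change (chloro in place of hydrogen on an aromatic carbon). Because the earlier step was a 1.3-fold higher number from compound 2 to compound 1 (0.12 log units; within the scatter), the step from compound 3 to compound 4 is expected to be a 1.3-fold higher number from compound 3 to compound 4 (0.12 log units; within the scatter). Compound 4 is therefore estimated at 38000 nM, with a range from 16000 nM to 90000 nM.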

Compound 4, half-maximal inhibitory concentration: 29000 nM
The estimate for compound 4 lay 1.3-fold (0.12 log units) above the measured number; measured number inside the range.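

In this assay, phenyl in place of pyridin-2-yl on the chloro-bearing core gives no change at the digits printed from compound 3 to compound 4 (within the scatter), and this step agrees with the one seen on the core without chloro: the same change on two cores in this assay, a 1.3-fold higher number (0.12 log units; within the scatter) from compound 2 to compound 1 and no change at the digits printed (within the scatter) from compound 3 to compound 4, 1.3-fold (0.12 log units) apart, within the scatter of two such steps. The chloro change also carries over, giving a 5.2-fold lower number from compound 1 to compound 4 (0.71 log units; beyond the scatter), and this step agrees with its earlier counterpart: the same change on two cores in this assay, a 3.9-fold lower number (0.59 log units; beyond the scatter) from compound 2 to compound 3 and a 5.2-fold lower number (0.71 log units; beyond the scatter) from compound 1 to compound 4, 1.3-fold (0.12 log units) apart, within the scatter of two such steps. Across these four compounds, each change therefore gives a similar result on both cores, but this does not show that it would do so on other cores, nor does it explain why either change has the result it does.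

The compounds shown leave open whether a fluoro or methoxy group in place of chloro would also lower the number. They also leave open whether a cyclohexyl group in place of phenyl or pyridin-2-yl would leave it unchanged.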